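The source may hold more compounds than are shown below. What is called first, only, known or untested is meant among the compounds shown, and "the series" means these compounds.

Working notes on the series, all in a functional assay on HepG2 cells (Homo sapiens) for antiproliferative activity, with a stated time of 72 h; a lower number here means that less compound is needed, a higher number that more compound is needed for the effect.

Of the compounds shown here, three sharing one core have been measured, and none gave a number. Compound 1 `COc1ccc(-c2cc(=O)c3c(OC)cc(OC)cc3n2S(=O)(=O)c2cc(F)c(F)c(F)c2)cc1` carries a 3,4,5-trifluorophenyl on the sulfonyl sulfur; in this assay compound 1 reaches only the limit > 65500 nM. Compound 2 `COc1ccc(-c2cc(=O)c3c(OC)cc(OC)cc3n2S(=O)(=O)c2ccc(Cl)cc2)cc1` carries a 4-chlorophenyl there; in this assay compound 2 likewise stops at the limit > 34400 nM. Compound 3 `COc1ccc(-c2cc(=O)c3c(OC)cc(OC)cc3n2S(=O)(=O)c2cccc(Br)c2)cc1` carries a 3-bromophenyl; in this assay compound 3 also stops at the limit > 58600 nM.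

Compound 3 therefore stands among three limits and is not ranked. The steps among the measured compounds are all unreadable: a step that the two limits leave unreadable from compound 1 to compound 2, a step that the two limits leave unreadable from compound 1 to compound 3 and a step that the two limits leave unreadable from compound 2 to compound 3. What the measurements do show is the limits themselves, (the limit of > 34400 nM in this assay, at which 1 of the 3 values shown sits), the limit of > 58600 nM in this assay, at which 1 of the 3 values shown sits, and (the limit of > 65500 nM in this assay, at which 1 of the 3 values shown sits).

Compound 4 `COc1ccc(-c2cc(=O)c3c(OC)cc(OC)cc3n2S(=O)(=O)c2ccc(C)cc2)cc1` differs from compound 3 by 4-methylphenyl in place of 3-bromophenyl on a sulfonyl sulfur. Every exchange of the aryl on the sulfonyl sulfur so far has left the read-out at a limit, so no measurable step is expected here either; the step from compound 3 to compound 4 is estimated as a step that the limit leaves unreadable from compound 3 to compound 4. For compound 4 the expected half-maximal effective concentration is 60000 nM, ranging from 15000 nM to 250000 nM, most probably reported once more as a limit.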

Compound 4, half-maximal effective concentration: > 44800 nM
Compound 4: only a limit was reported; the forecaster's own chance of this, stated with the estimate: 80%; the middle value lies beyond the limit too.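

Compound 4 also stops at a limit in this assay, so its steps to compound 1, compound 2 and compound 3 cannot be read: the limit of > 44800 nM in this assay, at which 1 of the 4 values shown sits.

The compounds shown leave open whether exchanging the aryl on the sulfonyl sulfur changes the half-maximal effective concentration at all, and how any of these four compounds would rank against the others.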